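The source may report more compounds than this note shows. Statements on the series, on what has been measured and on what is new or still open speak of the compounds shown alone.

Measured compounds in a functional assay on HL-60 cells (Homo sapiens) for cytotoxicity, read by CCK-8 assay, with a stated time of 72 h; on this read-out higher numbers stand for weaker inhibition and lower numbers for stronger inhibition:
compound 1 `C=CCn1c(=O)/c(=C\c2ccccc2Cl)[nH]c(=O)/c1=C\c1ccccc1OC`, 4200 nM
compound 2 `C=CCn1c(=O)/c(=C\c2cc(Br)ccc2F)[nH]c(=O)/c1=C\c1ccccc1OC`, 17400 nM
compound 3 `C=CCn1c(=O)/c(=C\c2cc(F)ccc2C)[nH]c(=O)/c1=C\c1ccccc1OC`, 2600 nM

Compound 1 sits second highest of the three numbers; compound 3 lies within the scatter of it, while compound 2 is set apart by a 4.1-fold higher number from compound 1 to compound 2 (0.62 log units; beyond the scatter). Compound 4 `C=CCn1c(=O)/c(=C\c2cccc(C)c2)[nH]c(=O)/c1=C\c1ccccc1OC` differs from compound 1 in one place: 3-methylphenyl in place of 2-chlorophenyl on a double-bonded chain carbon bound to an aromatic carbon. Only changes of this aryl group have been measured: a 1.6-fold lower number from compound 1 to compound 3 (0.21 log units; within the scatter) stays within the scatter, a 6.7-fold lower number from compound 2 to compound 3 (0.83 log units; beyond the scatter) is modest. Going by the values given here, no measured compound carries a 3-methylphenyl, so the step to compound 4 in this assay is expected to be small, likely within the scatter, with a slight lean toward a higher number. Compound 4 is estimated at 5000 nM, range 2000 nM to 14000 nM, which means an expected step of a 1.2-fold higher number from compound 1 to compound 4 (0.08 log units; within the scatter).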

Compound 4, half-maximal inhibitory concentration: 16700 nM
The estimate for compound 4 lay 3.3-fold (0.52 log units) below the measured number, outside the stated range (above it).
By their numbers in this assay, from the lowest: compounds 3 and 1 (each within the scatter of the next); then compounds 4 and 2 (each within the scatter of the next).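

In this assay, this position proves sensitive to a plain 3-methylphenyl: a 4.0-fold higher number from compound 1 to compound 4 (0.60 log units; beyond the scatter) and a 6.4-fold higher number from compound 3 to compound 4 (0.81 log units; beyond the scatter) are both beyond the scatter. By contrast, a 1.0-fold lower number from compound 2 to compound 4 (0.02 log units; within the scatter) stays within the scatter, so 3-methylphenyl and 5-bromo-2-fluorophenyl give matching numbers despite sharing no substituent. No measured evidence bears on these steps.

Open, from the compounds shown here alone, is whether 2-methylphenyl would stay with compound 3 or with compound 4. Also open, going by these compounds, is how an amine or a carboxylic acid on this aryl ring would read here.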